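Notes on the step from compound 3 to compound 4

A few compounds are considered here, and "the series" means these few. Any claim that something is new, unique, unknown or untested is made for them only; others in the source may bear on it.

Compound 3 `COc1cc(C#N)cc(-c2c(C)nn(-c3nc(-c4ccc(Cl)c(Cl)c4)c(SC(C)C)s3)c2C(=O)O)c1` carries a 3-cyano-5-methoxyphenyl group on the shared core. Going by the values given here, in a functional assay on BJAB cells (Homo sapiens) for antiproliferative activity, with a stated time of 4 days (a higher number here means that more compound is needed for the effect, a lower number that less compound is needed), compound 3 gives 5200 nM, the second highest of the three numbers measured so far. Compound 1 `COc1ccc(-c2c(C)nn(-c3nc(-c4ccc(Cl)c(Cl)c4)c(SC(C)C)s3)c2C(=O)O)cc1` gives 2100 nM, and the change to the 3-cyano-5-methoxyphenyl compound is a 2.5-fold higher number from compound 1 to compound 3 (0.39 log units; beyond the scatter). Compound 2 `Cc1cccc(-c2c(C)nn(-c3nc(-c4ccc(Cl)c(Cl)c4)c(SC(C)C)s3)c2C(=O)O)c1` gives 17000 nM, and the corresponding step is a 3.3-fold lower number from compound 2 to compound 3 (0.51 log units; beyond the scatter). The remaining measured step is an 8.1-fold higher number from compound 1 to compound 2 (0.91 log units; beyond the scatter).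

Compound 4 `Cc1nn(-c2nc(-c3ccc(Cl)c(Cl)c3)c(SC(C)C)s2)c(C(=O)O)c1Cc1ccccc1[N+](=O)[O-]` has not been measured. Its change from compound 3 is 2-nitrobenzyl in place of 3-cyano-5-methoxyphenyl on an aromatic carbon. Among the compounds with values here, none of the measured steps covers this kind of change: all three exchange one substituted phenyl for another at the same place, and their sizes, from the smallest to the largest, are modest. They show that the place accepts changes with modest movement in either direction, but none of them exchanges an aromatic group for a benzyl group, so they give no direct guide to the size or direction here.

Compound 4 is therefore expected to give about 9000 nM, with a wide range from 2000 nM to 40000 nM. The step this estimate means, a 1.7-fold higher number from compound 3 to compound 4 (0.24 log units; within the scatter), is expected to lie beyond the scatter only weakly, and the direction is uncertain.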

Compound 4, half-maximal effective concentration: 20000 nM
Beside the measured number, compound 4's estimate is 2.2-fold (0.35 log units) below it, within the range that was stated.
By their numbers in this assay, from the lowest: compound 1; then compound 3; then compounds 2 and 4 (each within the scatter of the next).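

Going by these compounds alone, the 2-nitrobenzyl group is the first group at this place that is not a directly attached substituted phenyl, and in this assay it gives a 3.8-fold higher number from compound 3 to compound 4 (0.59 log units; beyond the scatter) and a 9.5-fold higher number from compound 1 to compound 4 (0.98 log units; beyond the scatter), so against these two compounds the exchange raises the number. Against the 3-methylphenyl compound it gives a 1.2-fold higher number from compound 2 to compound 4 (0.07 log units; within the scatter), so a benzyl group here can be told apart from one substituted phenyl but not from another, and a change from phenyl to benzyl has no single effect across the three comparisons. No measurement at hand accounts for these differences.

The shared result leaves open whether the higher number follows the benzyl form or the nitro group, as the series holds no comparison that changes one without the other; an unsubstituted benzyl group and a 2-nitrophenyl group at this place would separate the two. A 4-methoxybenzyl group would show whether the 4-methoxy substituent of compound 1, which has the lowest number of the four, keeps that standing once it is carried on a benzyl group.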